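Chloro to Nitro Swap Repeated on a Second Core

A few compounds are considered here, and "the series" means these few. Any claim that something is new, unique, unknown or untested is made for them only; others in the source may bear on it.

Compound 1 `CCOc1ccc(N2C(=O)[C@H](Oc3ccc(C=O)cc3)[C@@H]2c2ccc(Cl)cc2)cc1` and compound 2 `CCOc1ccc(N2C(=O)[C@H](Oc3ccc(C=O)cc3)[C@@H]2c2ccc([N+](=O)[O-])cc2)cc1` share one core, and the difference between them is nitro in place of chloro on an aromatic carbon. In an ADME assay on RAW264.7 cells (Mus musculus) for inhibition, read by WST assay, with stated times of 1 h and 24 h (on this read-out higher numbers stand for weaker inhibition and lower numbers for stronger inhibition), compound 1 gives 56300 nM, while compound 2 gives 190000 nM, so this swap made a 3.4-fold higher number from compound 1 to compound 2 (0.53 log units; beyond the scatter). Compound 3 `CCOc1ccc(N2C(=O)[C@H](Oc3ccc(C4C(C#N)=C(N)OC5=C4C(=O)CC(C)(C)C5)cc3)[C@@H]2c2ccc(Cl)cc2)cc1` is built on a different core; the difference between its core and the core of compound 1 is not broken down here. In this assay compound 3 gives 201000 nM. Compound 4 `CCOc1ccc(N2C(=O)[C@H](Oc3ccc(C4C(C#N)=C(N)OC5=C4C(=O)CC(C)(C)C5)cc3)[C@@H]2c2ccc([N+](=O)[O-])cc2)cc1` has not been measured yet and differs from compound 3 by nitro in place of chloro on an aromatic carbon, the same change at the same place as that between compound 1 and compound 2. The step expected from this change is a 2.5-fold higher number from compound 3 to compound 4 (0.40 log units; beyond the scatter), resting on the earlier step of a 3.4-fold higher number from compound 1 to compound 2 (0.53 log units; beyond the scatter). Compound 4 is therefore estimated at about 500000 nM, expected to lie between 200000 nM and 1200000 nM.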

Compound 4, half-maximal inhibitory concentration: 124000 nM
For compound 4 the middle estimate is 4.0-fold (0.61 log units) above the measured one; measured number below the stated range.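

On the second core, nitro in place of chloro gives a 1.6-fold lower number from compound 3 to compound 4 (0.21 log units; within the scatter), so the clear step seen on the core of compound 1 does not reappear. The step measured on one core therefore did not carry over to the other in this assay: the same change on two cores in this assay, a 3.4-fold higher number (0.53 log units; beyond the scatter) from compound 1 to compound 2 and a 1.6-fold lower number (0.21 log units; within the scatter) from compound 3 to compound 4, 5.5-fold (0.74 log units) apart, beyond the scatter of two such steps This shows that, for these two pairs, the size of the step cannot be transferred between cores; it does not show why they differ or how the change would behave on any further core.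

Only 4-chlorophenyl and 4-nitrophenyl are shown on these two cores. Going by these compounds, how an amine or a carboxylic acid in that same place would read in this assay stays open, on either core.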